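From compound 3 to compound 4: one group exchanged

A few compounds are considered here, and "the series" means these few. Any claim that something is new, unique, unknown or untested is made for them only; others in the source may bear on it.

In a functional assay on DU-145 cells (Homo sapiens) for inhibition, read by trypan blue exclusion, with a stated time of 96 h (a lower number here means a stronger inhibitor of growth, a higher number a weaker inhibitor of growth), three compounds have been measured so far. Compound 1 (`O=C(/C(=C\c1ccc(Br)cc1)SCc1ccc(Cl)cc1)c1ccc(Br)cc1`) stands at 1000 nM and compound 3 (`Cc1cc(C)cc(/C=C(/SCc2ccc(F)cc2)C(=O)c2ccc(Br)cc2)c1`) at 10000 nM while compound 2 (`O=C(/C(=C\c1ccc(F)c([N+](=O)[O-])c1)S(=O)(=O)c1ccc(Br)cc1)c1ccc(Br)cc1`) reaches 25000 nM on the same scale. Compound 3 therefore holds the middle place, with compound 1 lower and compound 2 higher, and both gaps lie beyond the usual scatter.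

The next compound is compound 4 (`COc1ccccc1/C=C(/SCc1ccc(F)cc1)C(=O)c1ccc(Br)cc1`). It differs from compound 3 in one place (2-methoxyphenyl in place of 3,5-dimethylphenyl on a double-bonded chain carbon bound to a double-bonded chain carbon) with 2-methoxyphenyl in place of 3,5-dimethylphenyl on a double-bonded chain carbon bound to a double-bonded chain carbon. Among the compounds with values here, no measured pair isolates this exchange, so any forecast is uncertain. The estimate simply starts from compound 3 at 10000 nM and allows for a wide range. The expected step of a 1.7-fold lower number from compound 3 to compound 4 (0.22 log units; within the scatter) is toward a lower number, but it is small and stays within the usual scatter. For compound 4 the estimated value is 6000 nM with an expected range from 2000 nM to 20000 nM in this forecast.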

Compound 4, concentration for 50% growth inhibition: 10000 nM
For compound 4 the middle estimate is 1.7-fold (0.22 log units) below the measured one; measured number inside the range.
By their numbers in this assay, from the lowest: compound 1; then compounds 3 and 4 (each within the scatter of the next); then compound 2.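

In this assay, within the data shown here, replacing 3,5-dimethylphenyl with 2-methoxyphenyl on a double-bonded chain carbon bound to a double-bonded chain carbon gives no change at the digits printed from compound 3 to compound 4 (within the scatter) in the first comparison here that isolates a single change. At this position, then, a ring with two methyl groups and no hydrogen-bond acceptor and a ring with one methoxy group and one hydrogen-bond acceptor read the same in this growth test. Nothing shown here explains why the two groups give the same reading.

This single pair cannot say whether other groups at this position would also leave the number unchanged. A phenyl ring bearing an amine or a carboxylic acid, or a pyridine ring, could test that, and compound 1 and compound 2 differ from this pair in more than one place, so they do not answer it.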